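A few compounds are considered here, and "the series" means these few. Any claim that something is new, unique, unknown or untested is made for them only; others in the source may bear on it.

Working notes on the series. Compound 1 `Cc1ccc(NCC2=NCCN2)cc1` is the parent; in a functional assay for agonist activity at Adrenergic receptor alpha-1 (Rattus norvegicus) (a higher number here means that more compound is needed for the effect, a lower number that less compound is needed), compound 1 gives 340 nM. Compound 2 `Cc1ccc(N(C)CC2=NCCN2)cc1` carries a methyl in place of hydrogen on the nitrogen on the aromatic ring, and in this assay compound 2 gives 300 nM. Among the compounds with values here, the only step measured so far is the one from compound 1 to compound 2: a 1.1-fold lower number from compound 1 to compound 2 (0.05 log units; within the scatter). On the two numbers shown, compound 2 stands at the lower of the two, with compound 1 nearest, and the gap between them lies within the scatter, so no order between them can be read.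

Compound 3 `CCN(CC1=NCCN1)c1ccc(C)cc1` continues in the same direction: methyl in place of hydrogen on a saturated chain carbon bound to a nitrogen on an aromatic ring; cut one bond further out, the change reads methyl to ethyl on that nitrogen. The step from compound 1 to compound 2 is the only one that bears on it, and it was within the scatter. Going from methyl to ethyl on the same nitrogen is therefore expected to give no step beyond the scatter, with at most a small drift to a higher number, a 1.3-fold higher number from compound 2 to compound 3 (0.10 log units; within the scatter). For compound 3 the expected value in this assay is 380 nM, with a range from 150 nM to 1000 nM.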

Compound 3, half-maximal effective concentration: 1600 nM
Estimate against measurement, compound 3: 4.2-fold (0.62 log units) below; the measured number lies above the stated range.
By their numbers in this assay, from the lowest: compounds 2 and 1 (each within the scatter of the next); then compound 3.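

At the nitrogen on the aromatic ring, the one added carbon that separates methyl from ethyl is what registers in this assay: methyl in place of hydrogen on the saturated chain carbon bound to that nitrogen gives a 5.3-fold higher number from compound 2 to compound 3 (0.73 log units; beyond the scatter) and stands beyond the scatter, whereas methyl in place of hydrogen on the nitrogen itself gave only a 1.1-fold lower number from compound 1 to compound 2 (0.05 log units; within the scatter) and stayed within it. Measured against the parent, ethyl in place of hydrogen on that nitrogen gives a 4.7-fold higher number from compound 1 to compound 3 (0.67 log units; beyond the scatter) and is also beyond the scatter, so this position is not indifferent to what it carries: hydrogen and methyl cannot be told apart here, while ethyl stands apart from both with the higher number. Nothing at hand explains why the change appears only with ethyl.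

From the compounds shown here alone, whether a longer chain such as propyl or butyl on the same nitrogen moves the number further in this direction, or levels off, stays open. A branched isopropyl or a cyclopropyl there would show whether the count of carbons alone tracks with the step.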